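Two Pyrazole Diesters and an Aryl Swap Not Yet Tested

The compounds below may be only part of what the source reports. "The series", "measured", "known", "first", "only" and "open" are said of these compounds alone.

Measured so far:
- compound 1, `CCOC(=O)c1c(-c2c(Cl)c3ccccc3oc2=O)nn(-c2ccc(OC)cc2)c1C(=O)OCC`: 18000 nM
- compound 2, `CCOC(=O)c1c(-c2cc3ccccc3oc2=O)nn(-c2cccc(C)c2)c1C(=O)OCC`: 52000 nM

In a functional assay on A549 cells (Homo sapiens) for cytotoxicity, read by MTT assay, with a stated time of 48 h (a higher number here means a weaker inhibitor, a lower number a stronger inhibitor), compound 2 gives 52000 nM, the higher of the two numbers; compound 1 gives 18000 nM, a gap beyond the usual scatter, though the two structures differ in more than one place, so no single cause can be read from it. Compound 3, `CCOC(=O)c1c(-c2cc3ccccc3oc2=O)nn(-c2ccc(OC)cc2)c1C(=O)OCC`, differs from compound 2 by 4-methoxyphenyl in place of 3-methylphenyl on an aromatic nitrogen. Among the compounds with values here, no measured pair isolates this change. A modest step toward a lower number is expected, because compound 1, which carries the same 4-methoxyphenyl group, gives 18000 nM. Compound 3 is estimated at 30000 nM (range 12000 nM to 80000 nM), a step of a 1.7-fold lower number from compound 2 to compound 3 (0.24 log units; within the scatter) that is expected to stay close to the scatter.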

Compound 3, half-maximal inhibitory concentration: 86000 nM
For compound 3 the middle estimate is 2.9-fold (0.46 log units) below the measured one; measured number above the stated range.
By their numbers in this assay, from the lowest: compound 1; then compounds 2 and 3 (each within the scatter of the next).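

In this assay, 4-methoxyphenyl in place of 3-methylphenyl on the aromatic nitrogen comes with a 1.7-fold higher number from compound 2 to compound 3 (0.22 log units; within the scatter), so no effect of this swap can be read at this position. Hydrogen in place of chloro on an aromatic carbon comes with a 4.8-fold higher number from compound 1 to compound 3 (0.68 log units; beyond the scatter), and this single change is the only one shown that lies beyond the scatter. No measurement shown explains either step. As far as these compounds go, what remains open is whether an amine or a carboxylic acid on that aromatic carbon would give a lower or higher number. From the compounds shown here alone, the effect of a longer chain in place of either ethoxycarbonyl group also remains open.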